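Three Limits and a Trifluoromethyl Substitution

The compounds below may be only part of what the source reports. "The series", "measured", "known", "first", "only" and "open" are said of these compounds alone.

Three compounds share one core and differ only in the aromatic group on a saturated chain carbon bound to a nitrogen on an aromatic ring. Compound 1 `OC[C@H]1O[C@@H](n2cnc3c(NCc4ccccc4F)ncnc32)[C@H](O)[C@@H]1O` carries a 2-fluorophenyl group there. In a functional assay on HOS cells (Homo sapiens) for antiproliferative activity, with a stated time of 72 h (a higher number here means a weaker inhibitor, a lower number a stronger inhibitor), compound 1 gives only a limit of the assay, > 166000 nM, not a number. Compound 2 `OC[C@H]1O[C@@H](n2cnc3c(NCc4cccc(F)c4)ncnc32)[C@H](O)[C@@H]1O` carries a 3-fluorophenyl group. In this assay compound 2 likewise gives a limit, > 166000 nM. Compound 3 `Cc1ccc(CNc2ncnc3c2ncn3[C@@H]2O[C@H](CO)[C@@H](O)[C@H]2O)cc1` carries a 4-methylphenyl group. In this assay compound 3 also gives a limit, > 166000 nM. Compound 3 therefore stands nowhere apart from the others: the steps a step that the two limits leave unreadable from compound 1 to compound 2, a step that the two limits leave unreadable from compound 1 to compound 3 and a step that the two limits leave unreadable from compound 2 to compound 3 have no readable size, and the limit of > 166000 nM in this assay, at which 3 of the 3 values shown sit, is all the evidence there is.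

Compound 4 `OC[C@H]1O[C@@H](n2cnc3c(NCc4cccc(C(F)(F)F)c4)ncnc32)[C@H](O)[C@@H]1O` is not yet measured. It differs from compound 3 as follows: 3-(trifluoromethyl)phenyl in place of 4-methylphenyl on a saturated chain carbon bound to a nitrogen on an aromatic ring. All three measured steps change the same position, yet none of them shows a direction or a size, so they allow no inference beyond the fact that every change tried so far left the value at the limit. Because the limit of > 166000 nM in this assay, at which 3 of the 3 values shown sit, holds for all three neighbours, compound 4 is expected to give a limit as well. The step that the limit leaves unreadable from compound 3 to compound 4 is the expected consequence. Compound 4 is estimated at 200000 nM, within a range from 80000 nM to 500000 nM.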

Compound 4, half-maximal inhibitory concentration: > 166000 nM
Compound 4: only a limit was reported; the forecaster's own chance of this, stated with the estimate: 85%; the middle value does not contradict the limit.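

Compound 4 gives only a limit of the assay, > 166000 nM. Its steps from compound 1, compound 2 and compound 3 therefore cannot be read, and the evidence stays as it was: the limit of > 166000 nM in this assay, at which 4 of the 4 values shown sit. The compounds shown leave open how strongly any of them acts in this assay, and whether changing the aromatic group matters at all.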